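A few compounds are considered here, and "the series" means these few. Any claim that something is new, unique, unknown or untested is made for them only; others in the source may bear on it.

Measured in a functional assay on DU-145 cells (Homo sapiens) for inhibition, read by MTT assay, with a stated time of 72 h; on this read-out lower numbers stand for stronger inhibition and higher numbers for weaker inhibition:

- Compound 1 `O=C(O)CCCCCCC(=O)Nc1ccc(C2=C(c3ccc(O)cc3)C3CC(S(=O)(=O)Oc4cccc5ccccc45)C2O3)cc1` gives 48600 nM
- Compound 2 `COc1ccccc1OS(=O)(=O)C1CC2OC1C(c1ccc(NC(=O)CCCCCCC(=O)NO)cc1)=C2c1ccc(O)cc1` gives 44700 nM
- Compound 3 `O=C(CCCCCCC(=O)Nc1ccc(C2=C(c3ccc(O)cc3)C3CC(S(=O)(=O)Oc4ccccc4)C2O3)cc1)NO` gives 37700 nM

Compound 3 does not stand apart on these numbers, since all three values lie within the usual scatter of one another. Compound 4 `O=C(CCCCCCC(=O)Nc1ccc(C2=C(c3ccc(O)cc3)C3CC(S(=O)(=O)Oc4cccc5ccccc45)C2O3)cc1)NO` differs from compound 3 in one place, with naphthalen-1-yl in place of phenyl on an oxygen. Among the measured compounds shown here, only one measured step changes this same aromatic group, hydrogen in place of methoxy on an aromatic carbon, and it is small: a 1.2-fold lower number from compound 2 to compound 3 (0.07 log units; within the scatter). Compound 1 also carries naphthalen-1-yl on that oxygen, though it differs from compound 4 elsewhere, and the value of compound 1, 48600 nM, stays within the scatter of the others. Neither observation points to a real shift in this assay, so no change beyond the scatter is expected. The estimated step is a 1.1-fold higher number from compound 3 to compound 4 (0.03 log units; within the scatter). The expected value for compound 4 is 40000 nM. The estimated range for compound 4 runs from 20000 nM to 80000 nM.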

Compound 4, half-maximal inhibitory concentration: 8570 nM
Compound 4: middle estimate off by 4.7-fold (0.67 log units), on the high side; the measured number lies below the stated range.
By their numbers in this assay, from the lowest: compound 4; then compounds 3, 2 and 1 (each within the scatter of the next).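

In this assay, among the compounds shown here, the group on the oxygen bound to the sulfonyl sulfur does change the number: naphthalen-1-yl in place of phenyl gives a 4.4-fold lower number from compound 3 to compound 4 (0.64 log units; beyond the scatter) and naphthalen-1-yl in place of 2-methoxyphenyl gives a 5.2-fold lower number from compound 2 to compound 4 (0.72 log units; beyond the scatter) while the only earlier change in this group, a 1.2-fold lower number from compound 2 to compound 3 (0.07 log units; within the scatter) stayed within the scatter. The naphthalen-1-yl group does not act alone here, since hydroxyamino in place of hydroxy on the carbonyl carbon gives a 5.7-fold lower number from compound 1 to compound 4 (0.75 log units; beyond the scatter) with naphthalen-1-yl present in both compounds. No measurement shown explains this result.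

From the compounds shown here alone, it remains open whether the lower number is specific to naphthalen-1-yl or would also appear with naphthalen-2-yl or benzyl on that oxygen. Also open, going by these compounds, is whether it would persist with a shorter chain leading to the hydroxyamino group.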